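A few compounds are considered here, and "the series" means these few. Any claim that something is new, unique, unknown or untested is made for them only; others in the source may bear on it.

Compound 1 `c1ccc2c(c1)CCC2NC1CCN(CCCc2c[nH]c3ccc(-n4cnnc4)cc23)CC1`: 280 nM
Compound 2 `O=S(=O)(NCC1CCN(CCCc2c[nH]c3ccc(-n4cnnc4)cc23)CC1)c1ccccc1`: 60 nM
Compound 3 `COC[C@H](NC1CCN(CCCc2c[nH]c3ccc(Cn4cncn4)cc23)CC1)c1ccc(F)cc1`: 1200 nM

Among the measured compounds shown here, in an assay on CHO cells for displacement of a labelled ligand from 5-hydroxytryptamine receptor 1B (Homo sapiens) (a higher number here means a weaker inhibitor, a lower number a stronger inhibitor), compound 1 gives 280 nM, the second highest of the three numbers measured so far. Compound 3 gives 1200 nM, while compound 2 gives 60 nM. For the measured compounds named here, the only single-site step among the measured compounds is a 4.7-fold lower number from compound 1 to compound 2 (0.67 log units; beyond the scatter), which swaps out the whole group on the saturated ring carbon rather than adding to it.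

Compound 4 `O[C@H]1Cc2ccccc2C1NC1CCN(CCCc2c[nH]c3ccc(-n4cnnc4)cc23)CC1` differs from compound 1 by hydroxy in place of hydrogen on a saturated ring carbon. Going by the values given here, no measured step introduces a hydroxy anywhere, so nothing bears directly on the change; the expectation is therefore a step that stays within the scatter. Compound 4 is estimated at 280 nM, with a range of 100 nM to 800 nM, the expected step being no change at the digits printed from compound 1 to compound 4 (within the scatter).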

Compound 4, half-maximal inhibitory concentration: 300 nM
The estimate for compound 4 lay 1.1-fold (0.03 log units) below the measured number; low and high end bracket the measured number.
By their numbers in this assay, from the lowest: compound 2; then compounds 1 and 4 (each within the scatter of the next); then compound 3.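

In this assay, hydroxy in place of hydrogen on a saturated ring carbon of the five-membered ring gives a 1.1-fold higher number from compound 1 to compound 4 (0.03 log units; within the scatter), so this position accepts the added oxygen with no step beyond the scatter. The ((phenylsulfonyl)amino)methyl group still stands apart from the hydroxylated group, with a 5.0-fold higher number from compound 2 to compound 4 (0.70 log units; beyond the scatter). No evidence on this result is available.

Going by these compounds, whether the same ring carbon would accept a methoxy or an amine remains open. On these data alone, the opposite configuration at the hydroxy-bearing carbon also remains open.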